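The source may report more compounds than this note shows. Statements on the series, on what has been measured and on what is new or still open speak of the compounds shown alone.

Working notes on the series in a functional assay on J774 cells (Mus musculus) for cytotoxicity, read by resazurin assay; on this read-out higher numbers stand for weaker inhibition and lower numbers for stronger inhibition: compound 1 (`OCCCCCC(O)c1ccc(-c2ccccc2F)cc1`) gives 22000 nM, compound 2 (`OCCCCCC(O)c1ccc(-c2ccc(F)cc2F)cc1`) gives 8000 nM and compound 3 (`COc1cc(F)ccc1-c1ccc(C(O)CCCCCO)cc1`) gives 70000 nM. Compound 2 has the lowest number of the three, and the other two both stand beyond the scatter from it.

Still unmeasured is compound 4 (`Cc1cc(C(O)CCCCCO)ccc1-c1ccc(F)cc1F`). Its difference from compound 2 is methyl in place of hydrogen on an aromatic carbon.

Going by the values given here, two measured steps bear on this change, though only indirectly. The first is a 2.8-fold lower number from compound 1 to compound 2 (0.44 log units; beyond the scatter), with fluoro in place of hydrogen. The second is an 8.8-fold higher number from compound 2 to compound 3 (0.94 log units; beyond the scatter), with methoxy in place of fluoro. Among the compounds with values here, neither is the same exchange as the one in compound 4, so together they give a scale of modest steps and no firm direction. A slight lean towards a higher number in this assay rests only on the methoxy step, an 8.8-fold higher number from compound 2 to compound 3 (0.94 log units; beyond the scatter), the one case where the entering group contains carbon.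

The expected step is small, probably within the scatter: a 1.4-fold higher number from compound 2 to compound 4 (0.14 log units; within the scatter). For compound 4 the estimated value is 11000 nM, with an expected range from 4000 nM to 30000 nM.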

Compound 4, half-maximal inhibitory concentration: 8000 nM
Compound 4: middle estimate off by 1.4-fold (0.14 log units), on the high side; the measured number falls inside the stated range.
By their numbers in this assay, from the lowest: compounds 2 and 4 (each within the scatter of the next); then compound 1; then compound 3.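

In this assay the methyl change reads as no change at the digits printed from compound 2 to compound 4 (within the scatter), so an aromatic carbon ortho to one group of 8 heavy atoms and meta to another can carry a methyl with no readable shift in the number. Going by these compounds alone, this is the first single change that stays within the scatter, whereas both earlier steps lie beyond it. Within the data shown here, the only earlier step with carbon in the entering group, an 8.8-fold higher number from compound 2 to compound 3 (0.94 log units; beyond the scatter), is methoxy in place of fluoro at a different place on the molecule, so it offers no guide to this position. Nothing available explains why the number holds here.

From the compounds shown here alone, whether this position accepts more than a methyl remains open: an ethyl, a primary amine or a carboxylic acid on the same aromatic carbon could shift the number in either direction, or leave it in place. Also open, going by these compounds, is whether the same methyl would leave the number unchanged with the substituents of compound 1 or compound 3 on the shared core.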